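Meta substituent swap on the shared alkyne core

A few compounds are considered here, and "the series" means these few. Any claim that something is new, unique, unknown or untested is made for them only; others in the source may bear on it.

Measured so far:
compound 1 `Cc1nc(C#Cc2cccc(Cl)c2)cs1`, in a functional assay on CHO cells for agonist activity at metabotropic glutamate receptor 5 (Homo sapiens), read by inositol phosphate accumulation (a higher number here means a weaker inhibitor, a lower number a stronger inhibitor), compound 1 gives 129 nM.
compound 2 `Cc1nc(C#Cc2cccc(C(F)(F)F)c2)cs1`, in this assay compound 2 gives 413 nM.
compound 3 `Cc1nc(C#Cc2cccc(C#N)c2)cs1`, in this assay compound 3 gives 0.94 nM.

Compound 3 stands lowest of the three numbers; its steps to compound 1 and compound 2 are both beyond the scatter, so it is the strongest inhibitor of the set. The step from chloro to trifluoromethyl is modest, a 3.2-fold higher number from compound 1 to compound 2 (0.51 log units; beyond the scatter), whereas the cyano group produces the large changes a 140-fold lower number from compound 1 to compound 3 (2.14 log units; beyond the scatter) and a 440-fold lower number from compound 2 to compound 3 (2.64 log units; beyond the scatter).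

Compound 4 `Cc1nc(C#Cc2cccc(O)c2)cs1` carries the change (hydroxy in place of cyano on an aromatic carbon). Within the data shown here, no measured step involves a hydroxy group, so the only bearing comes from the two large steps into compound 3, both of which rest on the cyano that now leaves. Removing the cyano is expected to give back most of that gain, a step in this assay of roughly a 210-fold higher number from compound 3 to compound 4 (2.33 log units; beyond the scatter). Compound 4 is therefore estimated at 200 nM, with a range from 20 nM to 2000 nM.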

Compound 4, half-maximal inhibitory concentration: 654 nM
Estimate against measurement, compound 4: 3.3-fold (0.51 log units) below; the range from low to high includes it.
By their numbers in this assay, from the lowest: compound 3; then compound 1; then compounds 2 and 4 (each within the scatter of the next).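

Of the groups on this aromatic carbon, cyano now stands apart from three replacements in this assay, and hydroxy for cyano gives a 700-fold higher number from compound 3 to compound 4 (2.84 log units; beyond the scatter) as the third large loss from compound 3. Among the replacements, the hydroxy and trifluoromethyl groups are not separated, with a 1.6-fold higher number from compound 2 to compound 4 (0.20 log units; within the scatter) inside the scatter, while hydroxy in place of chloro gives a 5.1-fold higher number from compound 1 to compound 4 (0.70 log units; beyond the scatter) as a modest step. The high potency of this set therefore rests on cyano alone, and nothing available accounts for this.

The compounds shown leave open whether any other group on this carbon, such as an amide, a carboxylic acid or an amine, can approach compound 3. They also leave open whether a longer chain ending in a nitrile keeps the gain seen with cyano.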